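Compound 3: a new group on the nitrogen

A few compounds are considered here, and "the series" means these few. Any claim that something is new, unique, unknown or untested is made for them only; others in the source may bear on it.

For the measured compounds named here, compound 2 `Cc1ccccc1Nc1nc(Nc2ccccn2)ncc1Cl` reads 11200 nM in a functional assay on MDA-MB-231 cells (Homo sapiens) for inhibition, read by CCK-8 assay, with a stated time of 48 h (a higher number here means a weaker inhibitor of growth, a lower number a stronger inhibitor of growth), and holds the lower of the two numbers so far. Compound 1 `Cc1ccccc1Nc1nc(Nc2cccnc2)ncc1Cl` reads 41200 nM in this assay as well. Compound 3 `Cc1ccccc1Nc1nc(NCc2ccncc2)ncc1Cl` carries (pyridin-4-yl)methyl in place of pyridin-2-yl on a nitrogen on an aromatic ring. Going by the values given here, compound 1 also lacks pyridin-2-yl, and the one measured step bearing on this is a 3.7-fold lower number from compound 1 to compound 2 (0.57 log units; beyond the scatter) so a rise of similar, modest size is expected, though a single step is thin evidence. The expected change is upward, a 2.2-fold higher number from compound 2 to compound 3 (0.35 log units; beyond the scatter) in this assay as estimated here. For compound 3 the estimate is 25000 nM (range 8000 nM to 70000 nM).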

Compound 3, concentration for 50% growth inhibition: > 100000 nM
Compound 3 was reported as a limit (the forecaster's own chance of this, stated with the estimate: 10%); middle value at least 4.0-fold (0.60 log units) from the limit.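

Compound 3 is reported only as a limit, not as a number: the limit of > 100000 nM in this assay, at which 1 of the 3 values shown sits. Replacing pyridin-2-yl with (pyridin-4-yl)methyl on this nitrogen gives an at least 8.9-fold higher number from compound 2 to compound 3 (0.95 log units; beyond the scatter), and replacing pyridin-3-yl with the same group gives an at least 2.4-fold higher number from compound 1 to compound 3 (0.38 log units; beyond the scatter). For the compounds shown here, the earlier compounds compared only two pyridine rings attached straight to the nitrogen, whereas this change weakens growth inhibition against both of them. Two things changed at once, the methyl link and the pyridine attachment point. A pyridin-4-yl group directly on the nitrogen, or a (pyridin-2-yl)methyl group, would help separate them.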